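A few compounds are considered here, and "the series" means these few. Any claim that something is new, unique, unknown or untested is made for them only; others in the source may bear on it.

Within the data shown here, in a functional assay on CLL cells (Homo sapiens) for cytotoxicity, read by MTT assay, with a stated time of 48 h (on this read-out lower numbers stand for an effect already at smaller amounts and higher numbers for an effect only at larger amounts of compound), compound 2 `C=C(CC)C(=O)c1ccc(OCC(=O)Nc2ccc(C(=O)O)cn2)c(Cl)c1Cl` gives 14900 nM, the only true number so far. Compound 1 `C=C(CC)C(=O)c1ccc(OCC(=O)NCC(=O)O)c(Cl)c1Cl` gives > 25000 nM, which is a limit of the assay and not a number. The next compound, compound 3 `C=C(CC)C(=O)c1ccc(OCC(=O)NC(CS)C(=O)OCC)c(Cl)c1Cl`, changes the group on the same amide-type nitrogen once more: 1-(ethoxycarbonyl)-2-sulfanylethyl in place of 5-carboxypyridin-2-yl on an amide-type nitrogen. Among the measured compounds shown here, only one measured step bears on this, an at least 1.6-fold lower number from compound 1 to compound 2 (0.22 log units; that floor lies within the scatter), and it also exchanges the group on that nitrogen, though between a different pair of groups. That single small step offers no firm guide to size or direction, so no shift beyond the scatter is expected in this assay, and the starting point remains compound 2 at 14900 nM. The estimated step is a 1.4-fold lower number from compound 2 to compound 3 (0.13 log units; within the scatter). For compound 3 the expected value is 11000 nM, with an estimated range of 3500 nM to 30000 nM.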

Compound 3, half-maximal effective concentration: 4800 nM
Beside the measured number, compound 3's estimate is 2.3-fold (0.36 log units) above it; measured number inside the range.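

Among these compounds, the group on the amide-type nitrogen can move the number beyond the scatter in this assay, and this is the first step here to do so (a 3.1-fold lower number from compound 2 to compound 3 (0.49 log units; beyond the scatter)). The open-chain 1-(ethoxycarbonyl)-2-sulfanylethyl also stands clearly apart from carboxymethyl (an at least 5.2-fold lower number from compound 1 to compound 3 (0.71 log units; beyond the scatter)). That second step gives only a floor, since compound 1 is held at a limit and not a number: the limit of > 25000 nM in this assay, at which 1 of the 3 values shown sits.

The change from compound 2 to compound 3 removes the ring and brings in both an ethyl ester and a sulfanyl group, so the compounds shown cannot say which of these parts goes with the lower number. Still open, going by these compounds, is what a 2-sulfanylethyl chain carrying a carboxylic acid in place of the ethyl ester would give, or an ethyl ester chain without the sulfanyl group.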